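A few compounds are considered here, and "the series" means these few. Any claim that something is new, unique, unknown or untested is made for them only; others in the source may bear on it.

Values in a functional assay on U-251 cells (Homo sapiens) for antiproliferative activity, read by MTT assay, with a stated time of 72 h; on this read-out higher numbers stand for weaker inhibition and lower numbers for stronger inhibition:
- compound 1 `O=C(Nc1ccc(Cl)c(-c2nnc3c(Cl)cccn23)c1)c1ccccn1` gives 79000 nM
- compound 2 `Cc1nc(C(=O)Nc2ccc(Cl)c(-c3nnc4c(Cl)cccn34)c2)cs1` gives 74300 nM
- compound 3 `O=C(Nc1ccc(Cl)c(-c2nnc3c(Cl)cccn23)c1)c1ccc(Cl)cc1` gives > 100000 nM as a limit, not a number

Compound 3 has no number on this assay, only a limit: the limit of > 100000 nM in this assay, at which 1 of the 3 values shown sits.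

Compound 4 `O=C(Nc1ccc(Cl)c(-c2nnc3c(Cl)cccn23)c1)c1ccc(Cl)cc1Cl` differs from compound 3 by one change: chloro in place of hydrogen on an aromatic carbon. This is chloro in place of hydrogen on an aromatic carbon, so that 4-chlorophenyl becomes 2,4-dichlorophenyl.

Among the measured compounds shown here, no measured step shows this change itself. The nearest evidence comes from exchanges of the whole group on the carbonyl carbon. The first is a 1.1-fold lower number from compound 1 to compound 2 (0.03 log units; within the scatter). The other two are an at least 1.2-fold higher number from compound 1 to compound 3 (0.10 log units; that floor lies within the scatter) and an at least 1.3-fold higher number from compound 2 to compound 3 (0.12 log units; that floor lies within the scatter). None of these exchanges shows a step beyond the scatter, so a single added chloro is expected to give no step beyond the scatter in this assay, and no direction is favoured. The estimated step is a number no higher from compound 3 to compound 4 (the limit leaves the size open). A limit rather than a number is also expected to be a likely outcome for this compound.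

Compound 4 is expected at 100000 nM, with an estimated range of 50000 nM to 200000 nM.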

Compound 4, half-maximal inhibitory concentration: > 100000 nM
Compound 4: only a limit was reported; the forecaster's own chance of this, stated with the estimate: 55%; the middle value sits exactly at the limit.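

In this assay, the step between compound 3 and compound 4 cannot be read, because both compounds rest on a limit: the limit of > 100000 nM in this assay, at which 2 of the 4 values shown sit.

What compound 4 adds is that a chloro at this place, ortho to a large group and meta to a chloro group, does not bring 4-chlorophenyl back to a readable number in this assay. The exchanges of the whole group give an at least 1.3-fold higher number from compound 2 to compound 4 (0.12 log units; that floor lies within the scatter) and an at least 1.2-fold higher number from compound 1 to compound 4 (0.10 log units; that floor lies within the scatter), so 2,4-dichlorophenyl is not separated from 2-methyl-1,3-thiazol-4-yl or pyridin-2-yl.

On these data alone, whether an amine or a methoxy group at this same place would give a number rather than a limit stays open, and so does the size of any effect of the chloro itself. Also open, as far as these compounds go, is whether a carboxylic acid on the phenyl ring, or a longer chain on the carbonyl carbon in place of the aromatic group, would separate from compound 1 and compound 2 by more than the scatter.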